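The source may hold more compounds than are shown below. What is called first, only, known or untested is meant among the compounds shown, and "the series" means these compounds.

Measured compounds: compound 3 `Cc1cnn(C(=O)N2CCCN(Cc3ccc(OCc4ccccc4)cc3)CC2)c1` gives 9500 nM; compound 1 `Cc1cnn(C(=O)NCc2ccc(OCc3ccccc3)cc2)c1` gives "not determined" (no result reported) and compound 2 `N#Cc1cnn(C(=O)NCc2ccc(OCc3ccccc3)cc2)c1` gives "not determined" (no result reported), so neither of them carries a reported number.

Compound 3 stands alone on the numbers shown: in an assay on membranes from brain for binding affinity to Monoacylglycerol lipase ABHD6 (Mus musculus), read by fluorescence, with stated times of 1 h and 30 min (on this read-out lower numbers stand for stronger inhibition and higher numbers for weaker inhibition), compound 3 gives 9500 nM, while compound 1 and compound 2 have no result at all. Compound 4 `N#Cc1cnn(C(=O)N2CCCN(Cc3ccc(OCc4ccccc4)cc3)CC2)c1` differs from compound 3 in one place: cyano in place of methyl on an aromatic carbon. Within the data shown here, no pair of measured compounds shows the effect of this exchange, so the direction rests on no observed step. The expected change from compound 3 to compound 4 is a 2.4-fold lower number from compound 3 to compound 4 (0.38 log units; beyond the scatter), a modest gain that may not clear the scatter. Compound 4 is estimated at 4000 nM, with a range from 800 nM to 20000 nM.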

Compound 4, half-maximal inhibitory concentration: 85 nM
Compound 4: the middle estimate sits 47-fold (1.67 log units) above what was measured, outside the stated range (below it).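

Among these compounds, the group on this aromatic carbon matters far more than the earlier compounds could show: in this assay, cyano in place of methyl gives a 110-fold lower number from compound 3 to compound 4 (2.05 log units; beyond the scatter). This exchange of one small group for another is enough to produce a large step. Nothing measured here explains the gain.

Compound 1 and compound 2 carry the same exchange but have no numbers, so whether it holds in their different remainder cannot be read. Also open, going by these compounds, is whether chloro or a carboxamide at this carbon would match cyano.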